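Series notes: fluoro to methoxy next step, all at limit

The source may report more compounds than this note shows. Statements on the series, on what has been measured and on what is new or still open speak of the compounds shown alone.

Compound 1 `Cc1cc(C(=O)O)ccc1-c1noc(-c2ccc(C3CCCCC3)cc2)n1` gives a limit in a functional assay on CHO cells with sphingosine 1-phosphate receptor 4 (Homo sapiens) as the target, read by GTPgammaS binding; a lower number here means that less compound is needed, a higher number that more compound is needed for the effect: > 10000 nM.
Compound 2 `Cc1cc(CC(=O)O)ccc1-c1noc(-c2ccc(C3CCCCC3)cc2)n1` gives a limit in this assay: > 10000 nM.
Compound 3 `Cc1cc(CCC(=O)O)ccc1-c1noc(-c2ccc(OC(C)C)c(F)c2)n1` gives a limit in this assay: > 10000 nM.

Among the compounds with values here, compound 3 stands at the assay limit, as do the other two, so every value shown sits at the limit of > 10000 nM in this assay, at which 3 of the 3 values shown sit, and no compound can be ranked against another. Within the data shown here, the one step with a shared frame, a step that the two limits leave unreadable from compound 1 to compound 2, is unreadable. The change to compound 4 `COc1cc(-c2nc(-c3ccc(CCC(=O)O)cc3C)no2)ccc1OC(C)C` is methoxy in place of fluoro on an aromatic carbon. Among the measured compounds shown here, no measured step covers this change, so nothing here sets its size or direction. Given that compound 3 sits at the limit, compound 4 is expected at 15000 nM, range 4000 nM to 60000 nM, most likely again reported only as a limit. The expected step is a step that the limit leaves unreadable from compound 3 to compound 4, within the scatter.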

Compound 4, half-maximal effective concentration: > 10000 nM
Compound 4 gave a limit, no number; the forecaster's own chance of this, stated with the estimate: 80%; the middle value lies beyond the limit too.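

No step can be read between compound 3 and compound 4, as both are reported only as limits: the limit of > 10000 nM in this assay, at which 4 of the 4 values shown sit.

The compounds shown leave open which change, if any, would give a measurable value in this assay.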